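Swapping the trimethoxyphenyl arm for a bromophenyl arm

This account rests on a few compounds, and the source may have more. Where it says the series, first, only, none or still open, it means among the compounds named here.

Compound 1 `COc1cc(-c2nc(SCc3cn(CC(=O)NC(=O)Nc4ccccn4)nn3)nc(Nc3cccc(C(F)(F)F)c3)c2C#N)cc(OC)c1OC` and compound 2 `COc1cc(-c2nc(SCc3cn(CC(=O)NC(=O)Nc4ccccn4)nn3)nc(Nc3cccc(Cl)c3)c2C#N)cc(OC)c1OC` share a core and were both tested in a functional assay on MGC-803 cells (Homo sapiens) for inhibition, read by MTT assay, with a stated time of 72 h; on this read-out lower numbers stand for stronger inhibition and higher numbers for weaker inhibition. Compound 1 gives 8210 nM, and compound 2 gives 15400 nM. Of the two numbers, compound 1 has the lower one, and the step of a 1.9-fold higher number from compound 1 to compound 2 (0.27 log units; within the scatter) stays within the usual scatter. Compound 3 `N#Cc1c(Nc2cccc(C(F)(F)F)c2)nc(SCc2cn(CC(=O)NC(=O)Nc3ccccn3)nn2)nc1-c1ccc(Br)cc1` has not yet been measured in this assay. It differs from compound 1 in one place: 4-bromophenyl in place of 3,4,5-trimethoxyphenyl on an aromatic carbon. Going by the values given here, no measured step touches this position; the only measured step, between compound 1 and compound 2, changes a different aromatic ring and was within the scatter. The expectation for compound 3 therefore rests on compound 1 alone and is estimated as a 1.5-fold higher number from compound 1 to compound 3 (0.16 log units; within the scatter), a step of uncertain direction. Compound 3 is expected to give about 12000 nM, within a range from 4000 nM to 40000 nM.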

Compound 3, half-maximal inhibitory concentration: 3600 nM
Beside the measured number, compound 3's estimate is 3.3-fold (0.52 log units) above it; the whole stated range lies above it.
By their numbers in this assay, from the lowest: compound 3; then compounds 1 and 2 (each within the scatter of the next).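

This position responds to change: in this assay, 4-bromophenyl in place of 3,4,5-trimethoxyphenyl gives a 2.3-fold lower number from compound 1 to compound 3 (0.36 log units; beyond the scatter), a modest step but the first shown here that lies beyond the scatter. Going by these compounds alone, the only earlier step changed a different aromatic ring, so it said nothing about this arm, whereas compound 3 shows that the trimethoxyphenyl arm is not needed for activity and that a smaller arm with no hydrogen-bond acceptors can give a lower number. No measurement at hand bears on why the number moved.

The swap removes three methoxy groups and adds a bromine in one move, so the compounds shown cannot separate those two changes. From the compounds shown here alone, how a plain phenyl or a 4-methoxyphenyl arm would compare remains open.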